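Working notes: ethyl-to-methyl step toward compound 4

The source may report more compounds than this note shows. Statements on the series, on what has been measured and on what is new or still open speak of the compounds shown alone.

Measured so far:
compound 1, `CCSc1cc(C)c(C(=O)N=C(N)N)cc1S(C)(=O)=O`, 5.9 nM
compound 2, `Cc1cc(SC(C)C)c(S(C)(=O)=O)cc1C(=O)N=C(N)N`, 12 nM
compound 3, `CCc1cc(Oc2cccnc2)c(S(C)(=O)=O)cc1C(=O)N=C(N)N`, 27 nM

All three were run in a functional assay for inhibition of sodium/hydrogen exchanger (Oryctolagus cuniculus); on this read-out higher numbers stand for weaker inhibition and lower numbers for stronger inhibition. Compound 1 and compound 2 share one core; compound 3 carries another, and the difference between the two cores is not broken down here. Compound 3 stands highest of the three. For the measured compounds named here, only one step between measured compounds is counted: a 2.0-fold lower number from compound 2 to compound 1 (0.31 log units; beyond the scatter), the change being (hydrogen in place of methyl on a saturated chain carbon bound to a saturated chain carbon and a sulfur).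

Compound 4, `Cc1cc(Oc2cccnc2)c(S(C)(=O)=O)cc1C(=O)N=C(N)N`, is not yet measured in this assay. It differs from compound 3 by hydrogen in place of methyl on a saturated chain carbon bound to an aromatic carbon. This is the same kind of change as from compound 2 to compound 1, but the place differs: there the carbon bearing the methyl was bound to a saturated chain carbon and a sulfur, here it is bound to an aromatic carbon. A step of similar modest size is expected, a 1.5-fold lower number from compound 3 to compound 4 (0.18 log units; within the scatter), resting on a 2.0-fold lower number from compound 2 to compound 1 (0.31 log units; beyond the scatter) and on compound 1 giving 5.9 nM and compound 2 giving 12 nM, both of which carry a methyl at that place. Compound 4 is estimated at 18 nM, expected between 7 nM and 45 nM.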

Compound 4, half-maximal inhibitory concentration: 8.8 nM
Estimate against measurement, compound 4: 2.0-fold (0.31 log units) above; the measured number falls inside the stated range.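

In this assay the change of ethyl to methyl gives a 3.1-fold lower number from compound 3 to compound 4 (0.49 log units; beyond the scatter), and set beside the earlier step of the same kind, the two do not differ in size: the same change on two cores in this assay, a 2.0-fold lower number (0.31 log units; beyond the scatter) from compound 2 to compound 1 and a 3.1-fold lower number (0.49 log units; beyond the scatter) from compound 3 to compound 4, 1.5-fold (0.18 log units) apart, within the scatter of two such steps. Hydrogen in place of methyl therefore carries from the core of compound 1 to the core of compound 4 with the same direction and no separable difference in size, although the carbon bearing the methyl is bound differently in the two pairs. This rests on two pairs only, so it shows neither a general rule for the series nor any reason for the agreement.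

On the core of compound 4, (pyridin-3-yl)oxy in place of isopropylsulfanyl gives a 1.4-fold lower number from compound 2 to compound 4 (0.13 log units; within the scatter) and in place of ethylsulfanyl gives a 1.5-fold higher number from compound 1 to compound 4 (0.17 log units; within the scatter), so neither exchange separates these compounds. Still open, going by these compounds, is whether the step continues with a longer chain such as propyl on the aromatic carbon, and how an amine in place of (pyridin-3-yl)oxy would read.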